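Changing the Group on the Carbonyl Carbon of Compound 3

The compounds below may be only part of what the source reports. "The series", "measured", "known", "first", "only" and "open" are said of these compounds alone.

Compound 3 `CCN1CCN(c2cc(C)c3cc(NC(=O)c4ccc5ccccc5n4)ccc3n2)CC1` gives 3760 nM in a functional assay on SK-BR-3 cells (Homo sapiens) for antiproliferative activity, read by MTT assay, with a stated time of 72 h (on this read-out higher numbers stand for weaker inhibition and lower numbers for stronger inhibition), the highest of the two numbers shown, though compound 1 `Cc1cc(NCCN2CCN(C)CC2)nc2ccc(NC(=O)c3ccc(Cl)c(Cl)c3)cc12` sits close by at 2690 nM, within the scatter. Compound 2 `Cc1cc(N(C)C)nc2ccc(NC(=O)c3ccc(Cl)c(Cl)c3)cc12` reaches only > 50000 nM in this assay, which is a limit of the assay rather than a number (the limit of > 50000 nM in this assay, at which 1 of the 3 values shown sits). Among the measured compounds shown here, the one measured step, an at least 18-fold higher number from compound 1 to compound 2 (1.26 log units; beyond the scatter), changes the amine side of the shared core and says nothing about the group on the carbonyl carbon. Compound 4 `CCN1CCN(c2cc(C)c3cc(NC(=O)c4ccccc4OC)ccc3n2)CC1` differs from compound 3 only there: 2-methoxyphenyl in place of quinolin-2-yl on a carbonyl carbon. For the measured compounds named here, no measured step bears on this change, so the expectation rests on the values of compound 3 alone. Compound 4 is expected to land near 6000 nM, between 2000 nM and 25000 nM, which would mean a 1.6-fold higher number from compound 3 to compound 4 (0.20 log units; within the scatter).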

Compound 4, half-maximal inhibitory concentration: 15700 nM
Compound 4: the middle estimate sits 2.6-fold (0.42 log units) below what was measured, within the range that was stated.
By their numbers in this assay, from the lowest: compounds 1 and 3 (each within the scatter of the next); then compound 4. At a limit, above all of these: compound 2.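

Replacing quinolin-2-yl with 2-methoxyphenyl gives a 4.2-fold higher number from compound 3 to compound 4 (0.62 log units; beyond the scatter), so the group on the carbonyl carbon affects the read-out, which the earlier step on the amine side could not show. This single change swaps a group of two aromatic rings, one containing nitrogen, for a single carbon ring bearing a methoxy group, so these features cannot be separated. Nothing measured here bears on the reason for this step.

As far as these compounds go, it remains open whether a plain phenyl or a pyridine ring on the carbonyl carbon would give a number closer to that of compound 3 or compound 4.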